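The source may report more compounds than this note shows. Statements on the series, on what has been measured and on what is new or still open speak of the compounds shown alone.

Measured in a functional assay on MCF7 cells (Homo sapiens) for antiproliferative activity, read by MTT assay, with a stated time of 48 h; a higher number here means a weaker inhibitor, a lower number a stronger inhibitor:
compound 1 `COc1ccc(C(=O)c2ccc(OC)c3c2C=CC(C)(C)O3)c(NC(=O)CO)c1` — 940 nM
compound 2 `COc1ccc(C(=O)c2ccc(OC)c3c2C=CC(C)(C)O3)c(NC(=O)CN)c1` — 1250 nM
compound 3 `C=C(c1ccc2c(c1)C=CC(C)(C)O2)c1ccc(OC)cc1NC(=O)CO` — 390 nM

Compound 4 `C=C(c1ccc2c(c1)C=CC(C)(C)O2)c1ccc(OC)cc1NC(=O)CN` has not yet been measured in this assay.

Compound 4 differs from compound 3 by amino in place of hydroxy on a saturated chain carbon bound to a carbonyl carbon. The same change has already been made from compound 1 to compound 2, (amino in place of hydroxy on a saturated chain carbon bound to a carbonyl carbon), where it gave a 1.3-fold higher number from compound 1 to compound 2 (0.12 log units; within the scatter). The surroundings of the change are described in the same words in both pairs. How the core of compound 3 differs from the core of compound 1 is not broken down here; in this assay compound 3 gives a lower number than compound 1, beyond the scatter.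

Going by the values given here, for compound 4 the expected step is a 1.3-fold higher number from compound 3 to compound 4 (0.11 log units; within the scatter), and a step of similar size is expected because a 1.3-fold higher number from compound 1 to compound 2 (0.12 log units; within the scatter) is the only measured instance of this change. Compound 4 is therefore estimated at 500 nM, with a likely range from 280 nM to 900 nM.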

Compound 4, half-maximal inhibitory concentration: 420 nM
Compound 4: the middle estimate sits 1.2-fold (0.08 log units) above what was measured; low and high end bracket the measured number.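

In this assay, amino in place of hydroxy on a saturated chain carbon bound to a carbonyl carbon gives a 1.1-fold higher number from compound 3 to compound 4 (0.03 log units; within the scatter). The change reads the same on both cores, with no gap between the two steps beyond the scatter: the same change on two cores in this assay, a 1.3-fold higher number (0.12 log units; within the scatter) from compound 1 to compound 2 and a 1.1-fold higher number (0.03 log units; within the scatter) from compound 3 to compound 4, 1.2-fold (0.09 log units) apart, within the scatter of two such steps. Going by these compounds alone, these are only two pairs in a single assay, so they show that the change carried over between these two cores, not that it would do so on any other core.

Still open, on these data alone, is whether a larger change at the same place would move the number beyond the scatter. A dimethylamine, a carboxylic acid or a longer chain in place of the aminomethyl would test this.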